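The source may hold more compounds than are shown below. What is called first, only, known or untested is meant among the compounds shown, and "the series" means these compounds.

Of the compounds shown here, three built on one shared core have been measured in a physicochemical assay for lipophilicity; a higher number here means a more lipophilic compound, a lower number a more polar compound. Compound 1 `CCCCCOc1ccc(-c2[nH]c3ccccc3c2C2=C(Br)C(=O)NC2=O)cc1` gives 4.2. Among the compounds with values here, compound 2 `O=C1NC(=O)C(c2c(-c3ccc(OCc4cccc5ccccc45)cc3)[nH]c3ccccc23)=C1Br` gives 3.76, and the single change that separates the two, naphthalen-1-yl in place of butyl on a saturated chain carbon bound to an oxygen on an aromatic ring, brings a number 0.44 log units lower from compound 1 to compound 2 (beyond the scatter). Compound 3 `COc1ccc2[nH]c(-c3ccccc3)c(C3=C(Br)C(=O)NC3=O)c2c1` gives 2.48, the lowest of the three numbers; compound 2 stands nearest and compound 1 furthest, both beyond the scatter. Compound 4 `CCCCCc1ccc2[nH]c(-c3ccccc3)c(C3=C(Br)C(=O)NC3=O)c2c1` is not yet measured and differs from compound 3 by pentyl in place of methoxy on an aromatic carbon. Within the data shown here, the only measured step concerns a different place, so it bears on this change only loosely. Compound 4 is therefore expected to give 4.4, between 3.8 and 5, an expected step of a number 1.92 log units higher from compound 3 to compound 4 (beyond the scatter).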

Compound 4, partition coefficient: 4.07
Compound 4: the middle estimate sits 0.33 log units above what was measured; measured number inside the range.
By their numbers in this assay, from the lowest: compound 3; then compound 2; then compounds 4 and 1 (each within the scatter of the next).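

At this aromatic carbon of the shared core, a change of chain moves this assay strongly: pentyl in place of methoxy gives a number 1.59 log units higher from compound 3 to compound 4 (beyond the scatter). Within the data shown here, this is the first step read at this position, and it is large, whereas the earlier step lay elsewhere. Nothing measured explains the size of this step, and the swap changes chain length and removes the oxygen together, so the two cannot be separated. As far as these compounds go, how propyl, a chain between methoxy and pentyl in length, would fall remains open. So does the effect of an amine on the same carbon.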